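Shortening the amide side chain to an aryl group

This account rests on a few compounds, and the source may have more. Where it says the series, first, only, none or still open, it means among the compounds named here.

Measured so far:
Compound 1, `O=C(CC1CCCC1)Nc1c(C(O)(C(F)(F)F)C(F)(F)F)ccc2ccccc12`, 81 nM
Compound 2, `O=C(CCc1ccccc1)Nc1c(C(O)(C(F)(F)F)C(F)(F)F)ccc2ccccc12`, 1750 nM

Both compounds were tested in an assay on LtK cells with ATP-sensitive inward rectifier potassium channel 11 (Homo sapiens) as the target; a higher number here means that more compound is needed for the effect, a lower number that less compound is needed. Within the data shown here, compound 2 stands as the higher of the two numbers, with compound 1 giving the lower one; the only step between them, a 22-fold higher number from compound 1 to compound 2 (1.33 log units; beyond the scatter), is large and beyond the scatter.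

Compound 3, `O=C(Nc1c(C(O)(C(F)(F)F)C(F)(F)F)ccc2ccccc12)c1cccc(Cl)c1`, has not yet been measured in this assay. It differs from compound 2 in one place: 3-chlorophenyl in place of phenethyl on a carbonyl carbon. Among the measured compounds shown here, no measured step bears directly on this change; the single step in hand, a 22-fold higher number from compound 1 to compound 2 (1.33 log units; beyond the scatter), replaces a cyclopentyl with a benzyl on the saturated chain carbon and says nothing about removing that chain altogether and binding an aromatic ring straight to the carbonyl. What can be said is that compound 2 holds the highest number seen, so there is room for a lower one.

On that basis compound 3 is expected to give a moderately lower number than compound 2, roughly a 2.9-fold lower number from compound 2 to compound 3 (0.46 log units; beyond the scatter), with wide uncertainty. Compound 3 is estimated at 600 nM, within a range of 120 nM to 3000 nM.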

Compound 3, half-maximal effective concentration: 98 nM
The estimate for compound 3 lay 6.1-fold (0.79 log units) above the measured number; measured number outside the range, below it.
By their numbers in this assay, from the lowest: compounds 1 and 3 (each within the scatter of the next); then compound 2.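

In this assay, the carbonyl carbon accepts an aromatic ring bound straight to it: 3-chlorophenyl in place of phenethyl gives an 18-fold lower number from compound 2 to compound 3 (1.25 log units; beyond the scatter), so a high number does not go with every aromatic side chain. Measured against cyclopentylmethyl on the same carbonyl carbon, 3-chlorophenyl gives a 1.2-fold higher number from compound 1 to compound 3 (0.08 log units; within the scatter), which puts a saturated ring on a chain and a chlorinated aromatic ring without a chain on the same level and shows that an aromatic ring in the side chain does not by itself bring a high number. Nothing available here accounts for why phenethyl stands apart from these two groups.

The compounds shown leave open what the chlorine contributes, since 3-chlorophenyl is the only group of its kind here and neither a plain phenyl nor a methoxyphenyl on the carbonyl carbon can be compared with it. They also do not separate the length of the chain from the presence of the aromatic ring, a question that a benzyl on the carbonyl carbon, lying in length between 3-chlorophenyl and phenethyl, would bear on directly.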